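The source may hold more compounds than are shown below. What is called first, only, known or untested is meant among the compounds shown, and "the series" means these compounds.

In a functional assay on MCF7 cells (Homo sapiens) for antiproliferative activity, read by sulforhodamine B assay, with a stated time of 48 h (a higher number here means a weaker inhibitor, a lower number a stronger inhibitor), compound 1 `O=C(CCCCCCN1C(=O)/C(=N\O)c2cc(Br)ccc21)NO` gives 1770 nM and compound 2 `O=C(CCCCCCN1C(=O)/C(=N\O)c2cc([N+](=O)[O-])ccc21)NO` gives 1340 nM. These two values lie within the scatter of each other, so compound 2 cannot be ranked apart from compound 1. Compound 3 `Cc1ccc2c(c1)/C(=N/O)C(=O)N2CCCCCCC(=O)NO` carries the change (methyl in place of nitro on an aromatic carbon), methyl in place of nitro on an aromatic carbon. Among the compounds with values here, the one measured step on this aromatic carbon is a 1.3-fold lower number from compound 1 to compound 2 (0.12 log units; within the scatter), nitro in place of bromo, and it stays within the scatter. No shift beyond the scatter is therefore expected in this assay. The estimated step is a 1.3-fold higher number from compound 2 to compound 3 (0.10 log units; within the scatter). For compound 3 the expected value is 1700 nM, with an estimated range of 800 nM to 3600 nM.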

Compound 3, half-maximal inhibitory concentration: 1190 nM
For compound 3 the middle estimate is 1.4-fold (0.15 log units) above the measured one; the range from low to high includes it.
By their numbers in this assay, from the lowest: compounds 3, 2 and 1 (each within the scatter of the next).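

In this assay, methyl at this aromatic carbon cannot be separated from nitro (a 1.1-fold lower number from compound 2 to compound 3 (0.05 log units; within the scatter)) or from bromo (a 1.5-fold lower number from compound 1 to compound 3 (0.17 log units; within the scatter)). The earlier pair compared only nitro and bromo; the series now includes methyl, a group of one heavy atom with no hydrogen-bond acceptors, and all three compounds remain within the scatter of each other.

Going by these compounds, whether an amine or a carboxylic acid on this carbon would produce a step beyond the scatter remains open, as does the effect of changes elsewhere on the shared core. No measurement at hand bears on the reason for these values.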